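The compounds below may be only part of what the source reports. "The series", "measured", "known", "first", "only" and "open" are said of these compounds alone.

Measured in an ADME assay on cells (Hepatocyte, Homo sapiens) for metabolic stability; a lower number here means that the compound disappears faster, a higher number that the compound lasts longer:
- Compound 1 `O=c1cc(N2CCN(CC3CCC(NS(=O)(=O)c4ccccc4)CC3)CC2)sc2c([N+](=O)[O-])cc(C(F)(F)F)cc12`: > 1.55 h (a limit of the assay, not a number)
- Compound 2 `O=C(OC1CCC(CN2CCN(c3cc(=O)c4cc(C(F)(F)F)cc([N+](=O)[O-])c4s3)CC2)CC1)c1ccc(C(F)(F)F)cc1`: 0.117 h

Among the measured compounds shown here, only two compounds have been tested in this assay, and compound 2 gives the only actual number, 0.117 h. The other result is the limit for compound 1, (the limit of > 1.55 h in this assay, at which 1 of the 2 values shown sits). Compound 2 therefore stands on the short-lived side of this small set.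

Compound 3 `O=C(OC1CCC(CN2CCN(c3cc(=O)c4cc(C(F)(F)F)cc([N+](=O)[O-])c4s3)CC2)CC1)C1CCCCC1` is built from compound 2 by a single change on a carbonyl carbon whose other neighbours are: oxygen next to a carbonyl group. There, cyclohexyl takes the place of 4-(trifluoromethyl)phenyl: cyclohexyl in place of 4-(trifluoromethyl)phenyl on a carbonyl carbon.

For the measured compounds named here, no measured pair shows what this exchange does, so the direction is only a tentative call. Compound 3 keeps the rest of compound 2, so the expectation starts from the 0.117 h of compound 2. A small rise is expected, not clearly beyond the usual scatter, and the expected step is a 1.7-fold higher number from compound 2 to compound 3 (0.23 log units; within the scatter). For compound 3 the estimated half-life is 0.2 h, with an expected range from 0.08 h to 0.6 h.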

Compound 3, half-life: 0.0967 h
Compound 3: middle estimate off by 2.1-fold (0.32 log units), on the high side; the range from low to high includes it.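

In this assay, cyclohexyl and 4-(trifluoromethyl)phenyl on the carbonyl carbon cannot be told apart, with a 1.2-fold lower number from compound 2 to compound 3 (0.08 log units; within the scatter). Across this pair, then, replacing the aromatic ring with a non-aromatic one, and removing the three fluorine atoms with it, leaves the half-life within the usual scatter, and compound 3 joins compound 2 at the short-lived end of the set. The wider exchange of (cyclohexylcarbonyl)oxy in place of (phenylsulfonyl)amino on a saturated ring carbon is a different matter, giving an at least 16-fold lower number from compound 1 to compound 3 (1.20 log units; beyond the scatter), a large step beyond the scatter whose size is open-ended, as the result for compound 1 is a limit and not a number: the limit of > 1.55 h in this assay, at which 1 of the 3 values shown sits.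

The step from compound 1 to compound 3 changes the linking atoms and the terminal ring together, so the compounds shown cannot say which of these parts accounts for it. On these data alone, it also remains open how a (cyclohexylcarbonyl)amino group would fare on the saturated ring carbon, and whether an open chain such as n-butyl on the carbonyl carbon would fall within the same scatter.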